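Swapping the thioether aryl group on the growth-inhibiting amide

The source may hold more compounds than are shown below. What is called first, only, known or untested is meant among the compounds shown, and "the series" means these compounds.

Compound 1 `COc1ccc(SCc2ccc(/C=C/C(=O)Nc3ccccc3N)cc2)cc1OC` stands highest of the two numbers measured: in a functional assay on A-375 cells (Homo sapiens) for inhibition, read by CCK-8 assay, with a stated time of 72 h, tested at 8 uM (on this read-out higher numbers stand for more inhibition of growth at the one concentration tested and lower numbers for less inhibition of growth), compound 1 gives 46.4%. Compound 2 `CC(C)(C)c1ccc(SCc2ccc(C(=O)Nc3ccccc3N)cc2)cc1`, which differs from it in several places at once, gives 33.1% in this assay. Compound 3 `CC(C)(C)c1ccc(SCc2ccc(/C=C/C(=O)Nc3ccccc3N)cc2)cc1` has not been measured; it differs from compound 1 by 4-(tert-butyl)phenyl in place of 3,4-dimethoxyphenyl on a sulfur. Among the compounds with values here, no single-change step is available to gauge this swap, and compound 2 only shows that a tert-butyl bearer can sit lower. A small downward step or none beyond the scatter is expected, a number 6.4 percentage points lower from compound 1 to compound 3 (within the scatter), so compound 3 is estimated at 40%, with a range of 26% to 54%.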

Compound 3, percent growth inhibition at one concentration: 35.5%
Beside the measured number, compound 3's estimate is 4.5 percentage points above it; low and high end bracket the measured number.
By their numbers in this assay, from the lowest: compounds 2 and 3 (each within the scatter of the next); then compound 1.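

Within the data shown here, the swap of 4-(tert-butyl)phenyl for 3,4-dimethoxyphenyl on a sulfur gives a number 10.9 percentage points lower from compound 1 to compound 3 (beyond the scatter) in this assay and is the first single-change reading at this position. The step is modest, and the higher number stays with the dimethoxy compound in this one pair, though the entering group has the same heavy-atom count and no oxygen. Nothing measured here accounts for the step.

On these data alone, whether a single methoxy group would retain the number of compound 1 remains open. So does how an amine or a carboxylic acid on this phenyl would read.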